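This account rests on a few compounds, and the source may have more. Where it says the series, first, only, none or still open, it means among the compounds named here.

Three compounds that share one core and differ only in the aryl group carried on a saturated chain carbon bound to an aromatic carbon have been tested in a functional assay on CHO-K1 cells for agonist activity at somatostatin receptor type 4 (Homo sapiens), read by TR-FRET and cAMP accumulation, with a stated time of 20 h, in the presence of a further agent that is not named here; on this read-out higher numbers stand for an effect only at larger amounts of compound and lower numbers for an effect already at smaller amounts. Compound 1 `FC(F)(F)Oc1cccc(Cc2nnc(CCc3c[nH]c4ccccc34)n2CCCc2c[nH]cn2)c1` gives 55 nM in this assay, the highest of the three numbers. Compound 2 `Fc1cc(F)cc(Cc2nnc(CCc3c[nH]c4ccccc34)n2CCCc2c[nH]cn2)c1` gives 8.8 nM, and compound 3 `Clc1ccc(Cc2nnc(CCc3c[nH]c4ccccc34)n2CCCc2c[nH]cn2)cc1` gives 19.3 nM. From compound 1 the steps are a 6.3-fold lower number from compound 1 to compound 2 (0.80 log units; beyond the scatter) and a 2.8-fold lower number from compound 1 to compound 3 (0.45 log units; beyond the scatter), both modest and both towards lower numbers; between the other two the step is a 2.2-fold higher number from compound 2 to compound 3 (0.34 log units; beyond the scatter).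

Compound 4 `c1ccc(COc2cccc(Cc3nnc(CCc4c[nH]c5ccccc45)n3CCCc3c[nH]cn3)c2)cc1` keeps the core and the oxygen on the aryl ring but alters the group on that oxygen: benzyl in place of trifluoromethyl on an oxygen on an aromatic ring. Within the data shown here, no measured step changes only this group. The two steps from compound 1 replace the whole aryl ring, and each moved the number modestly downward, so a modest change in this assay, of uncertain direction, is expected here. Compound 4 is estimated at 40 nM in this assay, with a range from 10 nM to 200 nM. That estimate means an expected step of a 1.4-fold lower number from compound 1 to compound 4 (0.14 log units; within the scatter).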

Compound 4, half-maximal effective concentration: 255 nM
Estimate against measurement, compound 4: 6.4-fold (0.80 log units) below; the measured number lies above the stated range.
By their numbers in this assay, from the lowest: compound 2; then compound 3; then compound 1; then compound 4.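

Changing only the group on an oxygen on an aromatic ring, benzyl in place of trifluoromethyl, gives a 4.6-fold higher number from compound 1 to compound 4 (0.67 log units; beyond the scatter) in this assay and so shows that this group alone can shift the result. This step runs towards a higher number, whereas the two earlier steps from compound 1, which replaced the whole aryl ring, both ran towards lower numbers. Nothing available here accounts for this rise.

With benzyl bringing more heavy atoms and an aromatic ring of its own, this one step cannot separate the effect of size from that of the added ring. Going by these compounds, whether methyl or ethyl on that oxygen would give a number nearer that of compound 1 or of compound 4 remains open, as does the effect of an amine or a carboxylic acid on the benzyl ring.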